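Chlorophenyl position shift on the nitrocatechol amide series

The compounds below may be only part of what the source reports. "The series", "measured", "known", "first", "only" and "open" are said of these compounds alone.

Among the compounds with values here, compound 2 (`N#C/C(=C\c1cc(O)c(O)c([N+](=O)[O-])c1)C(=O)Nc1cccc(Cl)c1`) carries the only numeric value in the set: in a functional assay on Bel-7402 cells (Homo sapiens) for antiproliferative activity, read by MTT assay (a higher number here means a weaker inhibitor, a lower number a stronger inhibitor), compound 2 gives 40.1 ug/mL. Compound 1 (`COc1ccc(NC(=O)/C(C#N)=C/c2cc(O)c(O)c([N+](=O)[O-])c2)cc1`) is known only by a limit: in this assay compound 1 gives > 100 ug/mL, a limit of the assay and not a number (the limit of > 100 ug/mL in this assay, at which 1 of the 2 values shown sits). Within the data shown here, the one measured step, an at least 2.4-fold lower number from compound 1 to compound 2 (0.39 log units; beyond the scatter), is a 3-chlorophenyl in place of 4-methoxyphenyl on an amide-type nitrogen. Compound 3 (`N#C/C(=C\c1cc(O)c(O)c([N+](=O)[O-])c1)C(=O)Nc1ccccc1Cl`) differs from compound 2 by 2-chlorophenyl in place of 3-chlorophenyl on an amide-type nitrogen. Among the measured compounds shown here, no measured step shifts the chlorine alone on this ring, so the single step bears only loosely on it, as it mixes a change of substituent with a change of position. For compound 3 in this assay no step beyond the scatter is expected in either direction, so the estimate is 45 ug/mL with a range of 15 ug/mL to 100 ug/mL. The expected step of a 1.1-fold higher number from compound 2 to compound 3 (0.05 log units; within the scatter) is accordingly small.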

Compound 3, half-maximal inhibitory concentration: 24 ug/mL
Compound 3: middle estimate off by 1.9-fold (0.27 log units), on the high side; the range from low to high includes it.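

In this assay, the shift from 3-chlorophenyl to 2-chlorophenyl on the amide-type nitrogen gives a 1.7-fold lower number from compound 2 to compound 3 (0.22 log units; within the scatter), so these two chlorine positions cannot be told apart here. In place of 4-methoxyphenyl, 2-chlorophenyl gives an at least 4.1-fold lower number from compound 1 to compound 3 (0.61 log units; beyond the scatter), so the gain first seen with 3-chlorophenyl is not tied to that single chlorine position. The size of that gain remains open-ended, as compound 1 is known only by a limit of the assay: the limit of > 100 ug/mL in this assay, at which 1 of the 3 values shown sits.

The compounds shown do not separate the effect of the substituent from that of its position, since chlorine and methoxy share no position on this ring. On these data alone, how 4-chlorophenyl, unsubstituted phenyl or 3-methoxyphenyl would read on this nitrogen remains open.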